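The compounds below may be only part of what the source reports. "The series", "measured", "known", "first", "only" and "open" are said of these compounds alone.

Compound 1 `C=C1C(=O)[C@]23C[C@@]1(O)CC[C@H]2c1ccc(O)c(C)c1[C@@H]3Cn1cc(-c2ccc(C(F)(F)F)cc2)nn1` is the reference point of this comparison. In a functional assay on HL-60 cells (Homo sapiens) for cytotoxicity, read by MTT assay, with a stated time of 4 days (on this read-out lower numbers stand for stronger inhibition and higher numbers for weaker inhibition), compound 1 gives 720 nM, the lowest of the two numbers recorded here. Compound 3 `C=C1C[C@]23C[C@@]1(O)CC[C@H]2c1cc(Br)c(O)c(C)c1[C@@H]3Cn1cc(-c2ccc(C(F)(F)F)cc2)nn1` gives 7380 nM in this assay, a gap from compound 1 that lies well beyond the usual scatter of repeated measurements. For compound 2 `C=C1C[C@]23C[C@@]1(O)CC[C@@H]2c1cccc(C)c1[C@@H]3Cn1cc(-c2ccccc2)nn1` the measurement in this assay returns only a limit, > 20000 nM, and not a number; this is the limit of > 20000 nM in this assay, at which 1 of the 3 values shown sits.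

For the measured compounds named here, no pair of measured compounds differs in just one place, so no measured step is available to calibrate the change that follows. Compound 4 `C=C1C(=O)[C@]23C[C@@]1(O)CC[C@H]2c1ccc(O)c(C)c1[C@@H]3Cn1cc(-c2ccc(F)cc2)nn1` differs from compound 1 in a single spot: fluoro in place of trifluoromethyl on an aromatic carbon. Seen one bond further out, 4-(trifluoromethyl)phenyl becomes 4-fluorophenyl.

The step from compound 1 to compound 4 in this assay, a 1.8-fold higher number from compound 1 to compound 4 (0.26 log units; within the scatter), is expected to be modest, toward weaker inhibition, and possibly within the scatter. Compound 4 is therefore estimated at 1300 nM in this assay, with a likely range from 450 nM to 4000 nM.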

Compound 4, half-maximal inhibitory concentration: 660 nM
For compound 4 the middle estimate is 2.0-fold (0.29 log units) above the measured one, and the stated range covers the measured number.
By their numbers in this assay, from the lowest: compounds 4 and 1 (each within the scatter of the next); then compound 3. At a limit, above all of these: compound 2.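

For the compounds shown here, the step of a 1.1-fold lower number from compound 1 to compound 4 (0.04 log units; within the scatter) in this assay is the first measured change in a single place. It shows that on this aromatic carbon, para to a large group, trifluoromethyl and fluoro cannot be told apart, even though the group shrinks from four heavy atoms to one. For this pair, then, the cytotoxicity read-out does not follow the number of heavy atoms in the group, and 4-fluorophenyl serves as well as 4-(trifluoromethyl)phenyl on the shared core.

Going by these compounds, it remains open whether plain hydrogen, an amine or a carboxylic acid at this spot would keep the number in the same range, or whether any group is needed there at all. Nothing measured here gives a reason why this step stays so small.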